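This account rests on a few compounds, and the source may have more. Where it says the series, first, only, none or still open, it means among the compounds named here.

Three compounds have been measured in a functional assay on MKN-45 cells (Homo sapiens) for cytotoxicity, read by MTT assay, with a stated time of 72 h; on this read-out lower numbers stand for stronger inhibition and higher numbers for weaker inhibition:

compound 1, `CN(C)CCn1cnnc1-c1cc(Oc2ccc(NC(=O)N/N=C/c3ccc(Cl)cc3Cl)cc2F)ccn1`, gives 750 nM
compound 2, `CN(C)CCn1cnnc1-c1cc(Oc2ccc(NC(=O)N/N=C/c3c[nH]c4ccccc34)cc2F)ccn1`, gives 790 nM
compound 3, `CN(C)CCn1cnnc1-c1cc(Oc2ccc(NC(=O)N/N=C/c3ccc(Cl)cc3)cc2F)ccn1`, gives 570 nM

Compound 3 stands at the low end of these three numbers, but this means little: the step of a 1.3-fold lower number from compound 1 to compound 3 (0.12 log units; within the scatter) and the step of a 1.4-fold lower number from compound 2 to compound 3 (0.14 log units; within the scatter) are both within the usual scatter, as is the step of a 1.1-fold higher number from compound 1 to compound 2 (0.02 log units; within the scatter). In short, swapping the aryl group that sits on the carbon with a double bond to nitrogen between 2,4-dichlorophenyl, 1H-indol-3-yl and 4-chlorophenyl has left the read-out essentially unchanged across these three compounds.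

Compound 4, `Cc1cc(/C=N/NC(=O)Nc2ccc(Oc3ccnc(-c4nncn4CCN(C)C)c3)c(F)c2)cc(C)c1O`, carries the change (4-hydroxy-3,5-dimethylphenyl in place of 4-chlorophenyl on a carbon with a double bond to nitrogen). Among the compounds with values here, none of the measured steps introduces a hydrogen-bond donor or acceptor at this place, so no step bears directly on it; the measured steps show only that three quite different aryl groups here gave numbers that cannot be told apart. On that basis the step of a 1.4-fold higher number from compound 3 to compound 4 (0.15 log units; within the scatter) is expected to be small, with no clear direction beyond the scatter. Within the data shown here, compound 4 is therefore estimated to give 800 nM in this assay, within a range from 300 nM to 2500 nM, the wide range reflecting that the entering group has no measured counterpart.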

Compound 4, half-maximal inhibitory concentration: 1510 nM
For compound 4 the middle estimate is 1.9-fold (0.28 log units) below the measured one; low and high end bracket the measured number.
By their numbers in this assay, from the lowest: compounds 3, 1, 2 and 4 (each within the scatter of the next, the first and the last beyond it).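

Within the data shown here, the aryl group on this carbon with a double bond to nitrogen is not wholly without effect in this assay: 4-hydroxy-3,5-dimethylphenyl in place of 4-chlorophenyl gives a 2.6-fold higher number from compound 3 to compound 4 (0.42 log units; beyond the scatter), the first step at this place to pass the usual scatter. The separation holds against compound 3 only, as the same entering group gives a 1.9-fold higher number from compound 2 to compound 4 (0.28 log units; within the scatter) when it replaces 1H-indol-3-yl and a 2.0-fold higher number from compound 1 to compound 4 (0.30 log units; within the scatter) when it replaces 2,4-dichlorophenyl, and neither of these steps can be told from the scatter. Unlike the groups before it, the entering group counts a hydrogen-bond donor and a hydrogen-bond acceptor, but no measurement at hand explains the step.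

The hydroxy group and the two methyl groups enter together here, so the compounds shown leave open which of them goes with the higher number. Also open, as far as these compounds go, is how the read-out would respond to an amine or a carboxylic acid on the aryl ring, or to a saturated ring such as cyclohexyl in place of the aryl group.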